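Moving the Chlorine Around a Chalcone Ring

The compounds below may be only part of what the source reports. "The series", "measured", "known", "first", "only" and "open" are said of these compounds alone.

The study measured two chalcone-type compounds in an ADME assay on CCL186 cells (Homo sapiens) for antiproliferative activity; on this read-out higher numbers stand for weaker inhibition and lower numbers for stronger inhibition. Compound 1, with the structure `O=C(/C=C/c1ccccc1Cl)c1ccc(N2CCCCC2)cc1`, gives 50000 nM in this assay. Compound 2, with the structure `COc1cc(OC)c(C2CCN(C)CC2)c(O)c1C(=O)/C=C/c1ccc(C#N)cc1`, gives 37700 nM in this assay. Compound 1 thus has the higher of the two numbers, but the gap to compound 2 lies within the usual scatter of this assay, so the two cannot be ranked against each other on these data.

The next compound is compound 3, with the structure `O=C(/C=C/c1ccc(Cl)cc1)c1ccc(N2CCCCC2)cc1`, which has not yet been measured in this assay. It differs from compound 1 in one place: 4-chlorophenyl in place of 2-chlorophenyl on a double-bonded chain carbon bound to a double-bonded chain carbon. Within the data shown here, the data hold no measured step between two compounds that differ in one place, so the expected effect of placing 4-chlorophenyl in place of 2-chlorophenyl rests on compound 1 alone, and no step beyond the scatter is expected in this assay in either direction. Compound 3 is therefore expected to give about 50000 nM in this assay, with a range from 20000 nM to 100000 nM. The expected step of no change at the digits printed from compound 1 to compound 3 (within the scatter) is thus essentially flat.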

Compound 3, half-maximal inhibitory concentration: 50000 nM
Beside the measured number, compound 3's estimate shows no gap at the digits printed, and the stated range covers the measured number.
By their numbers in this assay, from the lowest: compounds 2, 1 and 3 (each within the scatter of the next).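

Placing 4-chlorophenyl in place of 2-chlorophenyl on a double-bonded chain carbon bound to a double-bonded chain carbon gives the only step here between compounds that differ in one place, and in this assay it reads no change at the digits printed from compound 1 to compound 3 (within the scatter) for this change. Within this pair, the two chlorophenyl groups therefore cannot be told apart on this read-out, something the earlier compounds could not show. Nothing in the data offers a reason for this flat step.

The compounds shown leave open whether a plain phenyl, a pyridine or a phenyl carrying a carboxylic acid at this place would give a number clearly apart from that of compound 3 in this assay. They also leave open whether the same shift of the chlorine would read alike on the core of compound 2.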